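A few compounds are considered here, and "the series" means these few. Any claim that something is new, unique, unknown or untested is made for them only; others in the source may bear on it.

Measured compounds:
compound 1, `CCOCc1cc(CN2CCCCC2)c(O)c2ncccc12`, 8710 nM
compound 2, `CCCOCc1cc(CN2CCCCC2)c(O)c2ncccc12`, 3720 nM
compound 3, `CCOCc1cc(CN2CCC(C)CC2)c(O)c2ncccc12`, 4070 nM

All three were tested in a functional assay on MES-SA cells (Homo sapiens) for inhibition, with a stated time of 72 h; on this read-out higher numbers stand for weaker inhibition and lower numbers for stronger inhibition. From compound 1 the change methyl in place of hydrogen on a saturated chain carbon, two bonds along the chain from an oxygen on a saturated carbon gives a 2.3-fold lower number from compound 1 to compound 2 (0.37 log units; beyond the scatter). From the same compound 1 the change methyl in place of hydrogen on a saturated ring carbon gives a 2.1-fold lower number from compound 1 to compound 3 (0.33 log units; beyond the scatter); compound 2 and compound 3 then lie within the scatter of each other.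

Compound 4, `CC1CCN(Cc2cc(COC(C)C)c3cccnc3c2O)CC1`, has not been measured. It differs from compound 3 by methyl in place of hydrogen on a saturated chain carbon bound to an oxygen on a saturated carbon and a saturated chain carbon. This is the same kind of change as that from compound 1 to compound 2, but not the same: there the methyl entered on a saturated chain carbon two bonds along the chain from an oxygen on a saturated carbon, here it enters on a saturated chain carbon bound to an oxygen on a saturated carbon and a saturated chain carbon. The cores of compound 3 and compound 1 differ by methyl in place of hydrogen on a saturated ring carbon.

Because the earlier step of a 2.3-fold lower number from compound 1 to compound 2 (0.37 log units; beyond the scatter) was modest, compound 4 is expected to show a step of about a 1.7-fold lower number from compound 3 to compound 4 (0.23 log units; within the scatter), somewhat smaller given the changed place. In this assay compound 4 is estimated at 2400 nM, between 1200 nM and 5000 nM.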

Compound 4, half-maximal inhibitory concentration: 2820 nM
Beside the measured number, compound 4's estimate is 1.2-fold (0.07 log units) below it; the range from low to high includes it.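

In this assay, going from ethoxymethyl to isopropoxymethyl on the core of compound 3 gives a 1.4-fold lower number from compound 3 to compound 4 (0.16 log units; within the scatter), a step that cannot be told apart from the scatter of repeated measurements. Set beside the earlier step, in which a methyl also entered the ether chain, it does not differ measurably: the same change on two cores in this assay, a 2.3-fold lower number (0.37 log units; beyond the scatter) from compound 1 to compound 2 and a 1.4-fold lower number (0.16 log units; within the scatter) from compound 3 to compound 4, 1.6-fold (0.21 log units) apart, within the scatter of two such steps. The pair is therefore compatible with such a methyl acting similarly on both cores, but it does not establish transfer: the second step is not itself beyond the scatter, the methyl enters at a different chain carbon in each step, and the comparison rests on only these two steps.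

The compounds shown leave open what a propoxymethyl group would give on the core of compound 3, which would compare the same chain on both cores. They also leave open how a longer chain such as butoxymethyl, or an amine at the end of the ether chain, would read in this assay.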